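Three Close Neighbours and a New Chlorinated Ring

The compounds below may be only part of what the source reports. "The series", "measured", "known", "first", "only" and "open" are said of these compounds alone.

Compound 1 `COc1cc(OC)c(OC)cc1/C=C/C(=O)c1ccc(Cl)cc1` gives 2.3 ug/mL
Compound 2 `COc1cc(OC)c(OC)cc1/C=C/C(=O)c1ccccc1` gives 2.23 ug/mL
Compound 3 `COc1cc(OC)c(OC)cc1/C=C/C(=O)c1ccc(O)cc1O` gives 2.37 ug/mL

These values all come from a functional assay on cells (Erythrocyte, Rattus norvegicus) for inhibition, read by hemolysis, with a stated time of 1 h (a lower number here means a stronger inhibitor, a higher number a weaker inhibitor), and they lie very close together. Compound 3 stands level with the other two, since a 1.1-fold higher number from compound 2 to compound 3 (0.03 log units; within the scatter) and a 1.0-fold higher number from compound 1 to compound 3 (0.01 log units; within the scatter) are both within the scatter of repeated measurements.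

Moving to compound 4 `COc1cc(OC)c(OC)cc1/C=C/C(=O)c1cc(Cl)ccc1O` puts 5-chloro-2-hydroxyphenyl in place of 2,4-dihydroxyphenyl on a carbonyl carbon while the rest of the molecule stays the same.

For the measured compounds named here, three measured steps bear on this change. Hydrogen took the place of chloro on an aromatic carbon in a 1.0-fold lower number from compound 1 to compound 2 (0.01 log units; within the scatter) and the result lay within the scatter. The 2,4-dihydroxyphenyl group replaced the chlorinated ring in a 1.0-fold higher number from compound 1 to compound 3 (0.01 log units; within the scatter) and replaced phenyl in a 1.1-fold higher number from compound 2 to compound 3 (0.03 log units; within the scatter) and neither step went beyond the scatter. Going by the values given here, no measured compound carries 5-chloro-2-hydroxyphenyl, so this reasoning leans on close neighbours and not on a direct comparison.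

No step beyond the scatter is therefore expected in this assay and the expected result is a 1.0-fold lower number from compound 3 to compound 4 (0.01 log units; within the scatter) in either direction. For compound 4 the estimated value is 2.3 ug/mL with an expected range from 1.3 ug/mL to 4.2 ug/mL as its likely span.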

Compound 4, half-maximal inhibitory concentration: 2.23 ug/mL
Compound 4: the middle estimate sits 1.0-fold (0.01 log units) above what was measured; the range from low to high includes it.
By their numbers in this assay, from the lowest: compounds 2, 4, 1 and 3 (each within the scatter of the next).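

The earlier compounds shown here carried either a chloro group or hydroxyl groups on the ring at this carbonyl carbon, and 5-chloro-2-hydroxyphenyl combines the two on one ring, yet in this assay the comparisons give a 1.1-fold lower number from compound 3 to compound 4 (0.03 log units; within the scatter) and a 1.0-fold lower number from compound 1 to compound 4 (0.01 log units; within the scatter) and no change at the digits printed from compound 2 to compound 4 (within the scatter) with all of them staying inside the usual spread of repeat measurements. The swap from compound 3 to compound 4 also goes from 2 hydrogen-bond donors and 2 hydrogen-bond acceptors on this ring to 1 of each, and this difference in the counts comes with no separation between the two compounds in this read-out. Nothing available explains why these four compounds stay so close together.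

As far as these compounds go, no change at this position has yet moved the number beyond the scatter, so how far this assay responds to the group on the carbonyl carbon remains open. An amine, a carboxylic acid or a longer chain on this ring could show whether that level holds for groups quite unlike chloro and hydroxyl, and the other side of the shared core, with its methoxy groups, stays the same in every compound here.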